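Methyl Added to a Methanesulfonamide Benzamide, Dosed in Mice

The compounds below may be only part of what the source reports. "The series", "measured", "known", "first", "only" and "open" are said of these compounds alone.

Measured so far:
compound 1 `CCN1CCCC1CNC(=O)c1cc(N(C)S(=O)(=O)N(C)C)c(C)cc1OC`, in a functional assay on the whole organism for inhibition, with Mus musculus as the target (on this read-out higher numbers stand for an effect only at larger amounts of compound and lower numbers for an effect already at smaller amounts), a limit of > 50 mg/kg and no number
compound 2 `CCN1CCCC1CNC(=O)c1cc(NS(C)(=O)=O)ccc1OC`, in this assay a limit of > 50 mg/kg and no number

Compound 2 stands at the limit of this assay, where both values shown sit, as the limit of > 50 mg/kg in this assay, at which 2 of the 2 values shown sit, states. Compound 3 `CCN1CCCC1CNC(=O)c1cc(NS(C)(=O)=O)c(C)cc1OC` differs from compound 2 by methyl in place of hydrogen on an aromatic carbon. For the measured compounds named here, no step between measured compounds is available. Compound 1 carries the same methyl and reaches only the limit > 50 mg/kg. For compound 3 a step that the limit leaves unreadable from compound 2 to compound 3 is therefore expected, none beyond the scatter. Compound 3 is estimated at 80 mg/kg, most likely again a limit, within 30 mg/kg to 300 mg/kg.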

Compound 3, dose for half-maximal effect: 35.6 mg/kg
For compound 3 the middle estimate is 2.2-fold (0.35 log units) above the measured one, and the stated range covers the measured number.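

With compound 3, the series gains its first actual number in this assay: methyl on the aromatic carbon ortho to the methanesulfonamido group gives an at least 1.4-fold lower number from compound 2 to compound 3 (0.14 log units; that floor lies within the scatter). With that methyl kept, methanesulfonamido in place of (dimethylsulfamoyl)(methyl)amino gives an at least 1.4-fold lower number from compound 1 to compound 3 (0.14 log units; that floor lies within the scatter). Both steps are only floors, so their true sizes cannot be read: the limit of > 50 mg/kg in this assay, at which 2 of the 3 values shown sit.

Going by these compounds, what an ethyl group or a chlorine atom on the same aromatic carbon would give remains open. So does the outcome of a larger group in place of the methyl.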